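The compounds below may be only part of what the source reports. "The series", "measured", "known", "first", "only" and "open" are said of these compounds alone.

Compound 1 `NC(=S)N/N=C/c1ccc2ccccc2n1` carries hydrogen on the amide-type nitrogen. In a functional assay on SGC-7901 cells (Homo sapiens) for antiproliferative activity, read by sulforhodamine B assay, with a stated time of 72 h (on this read-out lower numbers stand for stronger inhibition and higher numbers for weaker inhibition), compound 1 gives 32700 nM, the lower end of the two numbers in hand, though its gap to compound 3 lies within the scatter. Compound 3 `S=C(NCc1ccccc1)N/N=C/c1ccc2ccccc2n1`, with benzyl in place of hydrogen on that nitrogen, gives 53700 nM in this assay, the step of a 1.6-fold higher number from compound 1 to compound 3 (0.22 log units; within the scatter). Compound 2 `Fc1ccccc1NC(=S)N/N=C/c1ccc2ccccc2n1`, with 2-fluorophenyl on the same nitrogen, reaches only a limit of this assay at > 100000 nM. Because of the limit of > 100000 nM in this assay, at which 1 of the 3 values shown sits, the step of an at least 3.0-fold higher number from compound 1 to compound 2 (0.48 log units; beyond the scatter) is a floor, not a number. Compound 4 `S=C(N/N=C/c1ccc2ccccc2n1)Nc1ccccc1` is not yet measured; against compound 1 the change is phenyl in place of hydrogen on an amide-type nitrogen. Both substitutions at this nitrogen bear on it: the 2-fluorophenyl step is at least modest and beyond the scatter, the benzyl step within it. Phenyl resembles 2-fluorophenyl more closely than benzyl does, so a weakening beyond the scatter is expected in this assay, with a real chance the result is again a limit. Compound 4 is expected at 70000 nM in this assay, between 25000 nM and 200000 nM. The expected step is a 2.1-fold higher number from compound 1 to compound 4 (0.33 log units; beyond the scatter).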

Compound 4, half-maximal inhibitory concentration: 26500 nM
For compound 4 the middle estimate is 2.6-fold (0.42 log units) above the measured one, within the range that was stated.
By their numbers in this assay, from the lowest: compounds 4, 1 and 3 (each within the scatter of the next, the first and the last beyond it). At a limit, above all of these: compound 2.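

In this assay, phenyl on the amide-type nitrogen leaves the number within the scatter of the unsubstituted compound, the step being a 1.2-fold lower number from compound 1 to compound 4 (0.09 log units; within the scatter), so a six-membered aromatic ring at this position does not by itself weaken the read-out. The loss seen with 2-fluorophenyl therefore depends on the fluoro among these compounds, and hydrogen in place of fluoro on an aromatic carbon gives an at least 3.7-fold lower number from compound 2 to compound 4 (0.57 log units; beyond the scatter), which is a floor and not a number: the limit of > 100000 nM in this assay, at which 1 of the 4 values shown sits. The position also separates phenyl from benzyl, with a 2.0-fold lower number from compound 3 to compound 4 (0.31 log units; beyond the scatter), a modest step just beyond the scatter.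

On these data alone, it remains open whether chloro or methoxy in place of fluoro on that aromatic carbon brings the same loss. As far as these compounds go, it is also open whether a longer chain such as phenethyl, or a chain ending in an amine, on this nitrogen moves the number beyond the scatter of compound 1.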